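From fluoro to chloro on the phenyl ring

The compounds below may be only part of what the source reports. "The series", "measured", "known", "first", "only" and "open" are said of these compounds alone.

Measured in a functional assay on HepG2 cells (Homo sapiens) for inhibition, read by MTT assay, with a stated time of 48 h; on this read-out lower numbers stand for stronger inhibition of growth and higher numbers for weaker inhibition of growth:
Compound 1 `Cn1cc(C2CC(c3ccccc3)=NN2C(=O)c2cccnc2Cl)c2ccccc21`: > 10000 nM (a limit)
Compound 2 `Cn1cc(C2CC(c3ccccc3)=NN2C(=O)c2cccnc2)c2cc(Br)ccc21`: 2520 nM
Compound 3 `Cn1cc(C2CC(c3ccc(F)cc3)=NN2C(=O)c2cccnc2)c2cc(Br)ccc21`: 480 nM

Compound 3 gives 480 nM, the lower of the two actual numbers in this assay. Compound 4 `Cn1cc(C2CC(c3ccc(Cl)cc3)=NN2C(=O)c2cccnc2)c2cc(Br)ccc21` carries chloro in place of fluoro on an aromatic carbon, para to a large group: chloro in place of fluoro on an aromatic carbon. Going by the values given here, one measured step bears on this change: a 5.3-fold lower number from compound 2 to compound 3 (0.72 log units; beyond the scatter), with fluoro in place of hydrogen on that same carbon. That step did not involve chloro, so it sets no direction here. The expected change is a 1.1-fold lower number from compound 3 to compound 4 (0.03 log units; within the scatter), with none beyond the scatter anticipated. Compound 4 is estimated at 450 nM, with an expected range of 150 nM to 1400 nM.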

Compound 4, concentration for 50% growth inhibition: 5800 nM
Beside the measured number, compound 4's estimate is 13-fold (1.11 log units) below it; the whole stated range lies below it.
By their numbers in this assay, from the lowest: compound 3; then compound 2; then compound 4. At a limit, above all of these: compound 1.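

This position separates the two halogens sharply: in this assay there is a 12-fold higher number from compound 3 to compound 4 (1.08 log units; beyond the scatter) as 4-fluorophenyl gives way to 4-chlorophenyl, and chloro also falls short of hydrogen on the same carbon, with a 2.3-fold higher number from compound 2 to compound 4 (0.36 log units; beyond the scatter) on that change. Fluoro and chloro therefore move the number in opposite directions from hydrogen, so the gain seen with fluoro does not carry over to chloro. Nothing shown here accounts for this split.

From the compounds shown here alone, whether a methoxy or a trifluoromethyl group on that carbon would go the way of fluoro or of chloro remains open.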